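Acetyl in Place of tert-Butyl on the Shared Core

The source may report more compounds than this note shows. Statements on the series, on what has been measured and on what is new or still open speak of the compounds shown alone.

Compound 1, `COc1ccc(-c2cc3nccc(-c4cc(OC)c(OC)c(OC)c4)n3n2)cc1N`, gives 283 nM in a functional assay on HeLa cells (Homo sapiens) for inhibition, read by CCK-8 assay, with a stated time of 48 h; on this read-out lower numbers stand for stronger inhibition and higher numbers for weaker inhibition.
Compound 2, `COc1cc(-c2ccnc3cc(-c4ccc5cc[nH]c5c4)nn23)cc(OC)c1OC`, gives 125 nM in this assay.
Compound 3, `COc1cc(-c2ccnc3cc(-c4ccc(C(C)(C)C)cc4)nn23)cc(OC)c1OC`, gives only a limit in this assay, namely > 10000 nM.

Compound 3 therefore stands at the weak end of the three measured compounds, and its number is not known beyond that limit (the limit of > 10000 nM in this assay, at which 1 of the 3 values shown sits). The two steps that lead to compound 3 are both large: an at least 35-fold higher number from compound 1 to compound 3 (1.54 log units; beyond the scatter) and an at least 80-fold higher number from compound 2 to compound 3 (1.90 log units; beyond the scatter). In both, a group that carries a hydrogen-bond donor or acceptor is replaced by 4-(tert-butyl)phenyl, and the number rises sharply.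

Compound 4, `COc1cc(-c2ccnc3cc(-c4ccc(C(C)=O)cc4)nn23)cc(OC)c1OC`, differs from compound 3 in one place: acetyl in place of tert-butyl on an aromatic carbon. The entering acetyl brings one hydrogen-bond acceptor, which the leaving tert-butyl lacks. Since both measured steps show that losing such groups raised the number by a large margin, a lower number is expected from compound 3 to compound 4, estimated as an at least 3.3-fold lower number from compound 3 to compound 4 (0.52 log units; beyond the scatter). Because compound 3 itself is only a limit, the size of this step is uncertain. For compound 4 the expected value in this assay is 3000 nM, with a range from 500 nM to 20000 nM.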

Compound 4, half-maximal inhibitory concentration: 1810 nM
Estimate against measurement, compound 4: 1.7-fold (0.22 log units) above, within the range that was stated.
By their numbers in this assay, from the lowest: compound 2; then compound 1; then compound 4. At a limit, above all of these: compound 3.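

Acetyl in place of tert-butyl brings inhibition in this assay back into a measurable range, with an at least 5.5-fold lower number from compound 3 to compound 4 (0.74 log units; beyond the scatter), so a group at the 4-position of this phenyl ring need not abolish activity. That step is only a minimum, and the value for compound 3 is a limit and not a number: the limit of > 10000 nM in this assay, at which 1 of the 4 values shown sits. Even so, 4-acetylphenyl does not match the other two groups at this position, with a 14-fold higher number from compound 2 to compound 4 (1.16 log units; beyond the scatter) and a 6.4-fold higher number from compound 1 to compound 4 (0.81 log units; beyond the scatter), so this swap recovers only part of the gap seen with compound 3.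

The compounds shown leave open whether the gain comes from the carbonyl and its hydrogen-bond acceptor or simply from the removal of tert-butyl. An amine, a hydroxyl or a carboxylic acid in the same place on the phenyl ring could help separate these two readings, and could show whether a simple phenyl substituent can approach 1H-indol-6-yl.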